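The compounds below may be only part of what the source reports. "The series", "measured", "known", "first", "only" and "open" are said of these compounds alone.

In a functional assay on MCF7 cells (Homo sapiens) for antiproliferative activity, read by MTT assay, with a stated time of 72 h (on this read-out higher numbers stand for weaker inhibition and lower numbers for stronger inhibition), compound 1 `O=C1O[C@H]([C@@H](O)Cn2cc(-c3ccc(Br)cc3)nn2)C(OCc2ccccc2)=C1OCc1ccccc1`, which carries 4-bromophenyl, gives 5620 nM. Compound 2 `O=C1O[C@H]([C@@H](O)Cn2cc(CNS(=O)(=O)c3ccc(F)cc3)nn2)C(OCc2ccccc2)=C1OCc1ccccc1` gives 26800 nM, and compound 3 `O=C1O[C@H]([C@@H](O)Cn2cc(CCCCl)nn2)C(OCc2ccccc2)=C1OCc1ccccc1`, which carries 3-chloropropyl, gives 24500 nM. Compound 3 therefore lies on the high, weaker side of these three numbers, level with compound 2 and well apart from compound 1.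

Compound 4 `O=C1O[C@H]([C@@H](O)Cn2cc(CCO)nn2)C(OCc2ccccc2)=C1OCc1ccccc1` keeps the shared core and changes only the end of the chain: hydroxy in place of chloromethyl on a saturated chain carbon, two bonds along the chain from an aromatic carbon. In words, this is hydroxy in place of chloromethyl on a saturated chain carbon, two bonds along the chain from an aromatic carbon, so 3-chloropropyl becomes 2-hydroxyethyl.

Within the data shown here, no measured step makes this exact exchange. The closest guide is a change within the chain, a 1.1-fold lower number from compound 2 to compound 3 (0.04 log units; within the scatter). The two modest steps, a 4.8-fold higher number from compound 1 to compound 2 (0.68 log units; beyond the scatter) and a 4.4-fold higher number from compound 1 to compound 3 (0.64 log units; beyond the scatter), both replace 4-bromophenyl, which compound 3 has already lost. On that evidence, no step beyond the scatter is expected in either direction, though this rests on very few compounds.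

The expected change is a 1.1-fold higher number from compound 3 to compound 4 (0.06 log units; within the scatter). For compound 4, the estimated value is 28000 nM, with an expected range of 11000 nM to 70000 nM.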

Compound 4, half-maximal inhibitory concentration: 63400 nM
Beside the measured number, compound 4's estimate is 2.3-fold (0.35 log units) below it; the measured number falls inside the stated range.
By their numbers in this assay, from the lowest: compound 1; then compounds 3 and 2 (each within the scatter of the next); then compound 4.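

The exchange of chloromethyl for hydroxy, on a saturated chain carbon two bonds along the chain from an aromatic carbon, gives in this assay a 2.6-fold higher number from compound 3 to compound 4 (0.41 log units; beyond the scatter), so the end of this chain does matter, which the level pair of compound 2 and compound 3 could not show. The non-aromatic groups at this place are therefore not interchangeable: the 2-hydroxyethyl chain also sits apart from the sulfonamide-bearing group, with a 2.4-fold higher number from compound 2 to compound 4 (0.37 log units; beyond the scatter), and compound 4 is now the weakest of the set, while the widest gap so far is an 11-fold higher number from compound 1 to compound 4 (1.05 log units; beyond the scatter), leaving compound 1 with its 4-bromophenyl as the strongest. No measurement shown gives a reason for these differences.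

The exchange both swaps the end group and shortens the chain, and the compounds shown do not separate these two changes; a 3-hydroxypropyl chain or a 2-chloroethyl chain would pull them apart. Also open, as far as these compounds go, is whether an amine or a carboxylic acid at the end of the chain would follow hydroxy, and whether a plain phenyl would stay close to 4-bromophenyl.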